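Replacing the hydroxycyclohexylmethyl arm of compound 1 with a carbamoylcyclobutyl

The source may hold more compounds than are shown below. What is called first, only, known or untested is meant among the compounds shown, and "the series" means these compounds.

Compound 1 `N#Cc1cnc(NCc2cnccc2C(F)(F)F)cc1NC[C@H]1CC[C@H](O)CC1` gives 2000 nM in an assay on isolated protein for inhibition of protein kinase C delta type (Homo sapiens), read by TR-FRET, with a stated time of 2 h (on this read-out lower numbers stand for stronger inhibition and higher numbers for weaker inhibition), the second highest of the three numbers seen so far. Compound 2 `N#Cc1cnc(NCc2ccccc2C(F)(F)F)cc1N[C@H]1C[C@@H](C(N)=O)C1` gives 4200 nM in this assay, a gap beyond the scatter, and compound 3 `COc1ncncc1CNc1cc(N[C@H]2CC[C@@H](O)CC2)c(C#N)cn1` gives 800 nM, lower than compound 1 by a gap also beyond the scatter. Compound 4 `CC1(C)[C@H](Nc2cc(NCc3cnccc3C(F)(F)F)ncc2C#N)C[C@H]1C(N)=O` keeps the core of compound 1 and differs in one place: 3-carbamoyl-2,2-dimethylcyclobutyl in place of (4-hydroxycyclohexyl)methyl on a nitrogen on an aromatic ring. Since compound 2 carries a carbamoyl-substituted cyclobutyl on the same nitrogen and gives 4200 nM, a modest weakening is expected for compound 4. The estimated step from compound 1 to compound 4 is a 1.5-fold higher number from compound 1 to compound 4 (0.18 log units; within the scatter). Compound 4 is expected to give about 3000 nM, between 1000 nM and 9000 nM.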

Compound 4, half-maximal inhibitory concentration: 900 nM
For compound 4 the middle estimate is 3.3-fold (0.52 log units) above the measured one; measured number outside the range, below it.
By their numbers in this assay, from the lowest: compounds 3 and 4 (each within the scatter of the next); then compound 1; then compound 2.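

In this assay the change brings a 2.2-fold lower number from compound 1 to compound 4 (0.35 log units; beyond the scatter) and so shows that, with the core of compound 1 held fixed, the nitrogen on an aromatic ring accepts 3-carbamoyl-2,2-dimethylcyclobutyl in place of (4-hydroxycyclohexyl)methyl with a modest gain in inhibition. This is the first comparison among these compounds that isolates a change at this position. Nothing available explains the gain. From the compounds shown here alone, whether it depends on the carbamoyl or on the two methyl groups stays open. Also open, going by these compounds, is whether a carboxylic acid or an amine on the cyclobutyl could replace the carbamoyl.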